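Swapping an Ether Link for a Ketone on a Furan Core

This account rests on a few compounds, and the source may have more. Where it says the series, first, only, none or still open, it means among the compounds named here.

Compound 1 `CC(C)(C)c1[nH]cnc1/C=c1\[nH]c(=O)/c(=C/c2cccc(C(=O)c3ccc(F)cc3)c2)[nH]c1=O` and compound 2 `CC(C)(C)c1[nH]cnc1/C=c1\[nH]c(=O)/c(=C/c2cccc(Oc3ccc(F)cc3)c2)[nH]c1=O` share one core and differ only in that ((4-fluorophenyl)carbonyl in place of 4-fluorophenoxy on an aromatic carbon). In a functional assay on BXPC-3 cells (Homo sapiens) for cytotoxicity, read by MTT assay, with a stated time of 72 h (on this read-out higher numbers stand for weaker inhibition and lower numbers for stronger inhibition), compound 1 gives 0.6 nM, while compound 2 gives 3.2 nM, so this change produced a 5.3-fold lower number from compound 2 to compound 1 (0.73 log units; beyond the scatter). Compound 3 `COCc1ccc(/C=c2\[nH]c(=O)/c(=C/c3cccc(Oc4ccc(F)cc4)c3)[nH]c2=O)o1` carries the same 4-fluorophenoxy group as compound 2 but on another core, the two cores differing in that (5-(methoxymethyl)furan-2-yl in place of 5-(tert-butyl)-1H-imidazol-4-yl on a double-bonded chain carbon bound to an aromatic carbon); in this assay compound 3 gives 6.6 nM, a step of a 2.1-fold higher number from compound 2 to compound 3 (0.31 log units; beyond the scatter). Compound 4 `COCc1ccc(/C=c2\[nH]c(=O)/c(=C/c3cccc(C(=O)c4ccc(F)cc4)c3)[nH]c2=O)o1` has not yet been measured. It stands to compound 3 exactly as compound 1 stands to compound 2: (4-fluorophenyl)carbonyl in place of 4-fluorophenoxy on an aromatic carbon, at the same place in both pairs, so it is the same change made a second time, its second occurrence among these compounds. Among the measured compounds shown here, compound 4 is expected to show a step of a 5.1-fold lower number from compound 3 to compound 4 (0.71 log units; beyond the scatter) in this assay, an expectation that rests on a single precedent because a 5.3-fold lower number from compound 2 to compound 1 (0.73 log units; beyond the scatter) is the only record of this change. Compound 4 is therefore estimated at 1.3 nM, most likely between 0.5 nM and 3.5 nM.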

Compound 4, half-maximal inhibitory concentration: 2 nM
The estimate for compound 4 lay 1.5-fold (0.19 log units) below the measured number, within the range that was stated.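

In this assay, putting (4-fluorophenyl)carbonyl in place of 4-fluorophenoxy acts in the same direction on the second core, giving a 3.3-fold lower number from compound 3 to compound 4 (0.52 log units; beyond the scatter), and the two occurrences agree as closely as such measurements allow: the same change on two cores in this assay, a 5.3-fold lower number (0.73 log units; beyond the scatter) from compound 2 to compound 1 and a 3.3-fold lower number (0.52 log units; beyond the scatter) from compound 3 to compound 4, 1.6-fold (0.21 log units) apart, within the scatter of two such steps. The swap between the two cores also repeats, giving a 3.3-fold higher number from compound 1 to compound 4 (0.52 log units; beyond the scatter), and it too matches its earlier occurrence: the same change on two cores in this assay, a 2.1-fold higher number (0.31 log units; beyond the scatter) from compound 2 to compound 3 and a 3.3-fold higher number (0.52 log units; beyond the scatter) from compound 1 to compound 4, 1.6-fold (0.21 log units) apart, within the scatter of two such steps. Among the compounds shown here, these are only two pairs of compounds in one cell assay, so they show that the change carried over between these two cores on this read-out, but they do not show that it would carry to any other core or explain why the number falls.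

The compounds shown leave open how another link at the same place, such as an amine or a methylene, would compare with the carbonyl and the ether. They also leave open whether the step would hold on a core carrying a carboxylic acid or a longer chain in place of the methoxymethyl group.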